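A few compounds are considered here, and "the series" means these few. Any claim that something is new, unique, unknown or untested is made for them only; others in the source may bear on it.

Measured compounds:
Compound 1 `COc1ccc(CNC(=O)/C(C#N)=C/c2ccc[nH]2)cc1`: > 50000 nM
Compound 2 `N#C/C(=C\c1ccc[nH]1)C(=O)NCc1ccc(Cl)c(Cl)c1`: > 50000 nM

The read-out is a functional assay on SW480 cells (Homo sapiens) for inhibition, read by MTT assay, with a stated time of 72 h; on this read-out higher numbers stand for weaker inhibition of growth and lower numbers for stronger inhibition of growth. In this assay compound 1 gives > 50000 nM, which is a limit of the assay rather than a number. Compound 2 gives > 50000 nM, which is likewise a limit. Compound 1 therefore stands at no particular point among the numbers shown: the limit of > 50000 nM in this assay, at which 2 of the 2 values shown sit. Going by the values given here, no measured step between the two compounds is available.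

Compound 3 `COc1ccc(CNC(=O)/C(C#N)=C/c2ccco2)cc1` has not yet been measured. It differs from compound 1 in one place: furan-2-yl in place of 1H-pyrrol-2-yl on a double-bonded chain carbon bound to a double-bonded chain carbon. The only footing for an expectation is compound 1, whose value > 50000 nM is a limit. The expected step from compound 1 to compound 3 is a number no higher from compound 1 to compound 3 (the limit leaves the size open), none beyond the usual scatter. For compound 3 the estimate in this assay is 50000 nM, in a range from 20000 nM to 200000 nM, with a fair chance that only a limit is reported again.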

Compound 3, concentration for 50% growth inhibition: 31000 nM
The estimate for compound 3 lay 1.6-fold (0.21 log units) above the measured number; low and high end bracket the measured number.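

In this assay, compound 3 is the only compound shown that gives a number rather than a limit, so furan-2-yl at this place allows a reading inside the range of the test, which 1H-pyrrol-2-yl did not. The change takes away the ring's hydrogen-bond donor and brings in a hydrogen-bond acceptor, and it reads as an at least 1.6-fold lower number from compound 1 to compound 3 (0.20 log units; that floor lies within the scatter). As far as these compounds go, this is only a floor, so the true size of the step stays open, and most of the values shown still sit at the edge of the test: the limit of > 50000 nM in this assay, at which 2 of the 3 values shown sit.

Open, from the compounds shown here alone, is whether another ring at this place, such as thiophen-2-yl or phenyl, would give a lower number still. Also open, going by these compounds, is whether furan-2-yl would give a number on the core of compound 2 as well.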